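A few compounds are considered here, and "the series" means these few. Any claim that something is new, unique, unknown or untested is made for them only; others in the source may bear on it.

Compound 2 `O=C(Nc1cccc(/C=C/C(=O)c2nc3ccccc3[nH]2)c1)c1ccc(Br)cc1` gives 7000 nM in a functional assay on MCF7 cells (Homo sapiens) for antiproliferative activity, read by MTT assay, with a stated time of 48 h (on this read-out higher numbers stand for weaker inhibition and lower numbers for stronger inhibition), the low end of the two values shown, though the step of a 1.6-fold lower number from compound 1 to compound 2 (0.20 log units; within the scatter) stays within the scatter; compound 1 `O=C(Nc1cccc(/C=C/C(=O)c2nc3ccccc3[nH]2)c1)c1ccccc1` gives 11200 nM in this assay. Compound 3 `Cc1ccccc1C(=O)Nc1cccc(/C=C/C(=O)c2nc3ccccc3[nH]2)c1` differs from compound 2 by 2-methylphenyl in place of 4-bromophenyl on a carbonyl carbon. Among the compounds with values here, only the step from compound 1 to compound 2 bears on this change, as it also alters the ring on that carbonyl carbon, and it was small. For compound 3 the expected step is therefore a 1.1-fold higher number from compound 2 to compound 3 (0.06 log units; within the scatter), nothing beyond the scatter. Compound 3 is estimated at 8000 nM, between 3500 nM and 18000 nM.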

Compound 3, half-maximal inhibitory concentration: 5870 nM
The estimate for compound 3 lay 1.4-fold (0.13 log units) above the measured number; measured number inside the range.
By their numbers in this assay, from the lowest: compounds 3, 2 and 1 (each within the scatter of the next).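

In this assay, 2-methylphenyl in place of 4-bromophenyl on the carbonyl carbon gives a 1.2-fold lower number from compound 2 to compound 3 (0.08 log units; within the scatter), and the added methyl group gives a 1.9-fold lower number from compound 1 to compound 3 (0.28 log units; within the scatter). A change of both substituent and printed ring position therefore still leaves all three compounds within the scatter of one another. Nothing available gives a reason for these numbers.

Still open, as far as these compounds go, is whether an amine or a carboxylic acid on this ring would give a step beyond the scatter. From the compounds shown here alone, a longer chain in place of the ring is equally open.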